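Chloro for Hydroxy Where Every Value Is a Limit

A few compounds are considered here, and "the series" means these few. Any claim that something is new, unique, unknown or untested is made for them only; others in the source may bear on it.

Three compounds have been examined in an ADME assay on Vero cells (Chlorocebus sabaeus) for cytotoxicity, read by MTT assay, with a stated time of 72 h; on this read-out higher numbers stand for weaker inhibition and lower numbers for stronger inhibition. Compound 1 `O=C(c1ccncc1)N1N=C(c2cc3ccccc3o2)CC1c1ccccc1O` reaches only a limit there, giving > 195000 nM. Compound 2 `O=C(c1ccncc1)N1N=C(c2cc3ccccc3o2)CC1c1ccc(O)cc1` likewise gives only a limit, > 200000 nM. The step that the two limits leave unreadable from compound 1 to compound 2 accordingly has no readable size. Compound 3 `CCn1cc(C(=O)N2N=C(c3cc4ccccc4o3)CC2c2ccccc2O)c(=O)c2ccc(C)nc21` also stands at a limit, giving > 157000 nM in this assay. Compound 3 cannot be ranked against the other two, as the three results are all limits: the limit of > 157000 nM in this assay, at which 1 of the 3 values shown sits, the limit of > 195000 nM in this assay, at which 1 of the 3 values shown sits, and (the limit of > 200000 nM in this assay, at which 1 of the 3 values shown sits).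

Compound 4 `CCn1cc(C(=O)N2N=C(c3cc4ccccc4o3)CC2c2ccccc2Cl)c(=O)c2ccc(C)nc21` differs from compound 3 in one place: chloro in place of hydroxy on an aromatic carbon. Among the measured compounds shown here, no measured step bears on this change; the single step in the set, a step that the two limits leave unreadable from compound 1 to compound 2, is unreadable, and no numerical value exists anywhere. The expectation for this assay is thus a step no larger than the scatter, with compound 4 expected to sit at the limit again. The estimate for compound 4 is 200000 nM, within 100000 nM to 400000 nM. This amounts to an expected step that the limit leaves unreadable from compound 3 to compound 4.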

Compound 4, half-maximal inhibitory concentration: > 178000 nM
Compound 4: a limit, no number; the forecaster's own chance of this, stated with the estimate: 85%; the middle value is on the limit's open side.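

Compound 3 and compound 4 both stand at limits, so no step can be read for chloro in place of hydroxy on the aromatic carbon. The compounds shown leave open what number, if any, each of the four would reach in this assay.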